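The source may report more compounds than this note shows. Statements on the series, on what has been measured and on what is new or still open speak of the compounds shown alone.

Going by the values given here, compound 3 `COc1ccc([C@@H]2CC(=O)c3c(O)cc(OCc4cn(Cc5ccccc5C)nn4)cc3O2)cc1O` gives 13100 nM in a functional assay on RAW264.7 cells (Mus musculus) for inhibition, read by Griess assay, with stated times of 2 h and 24 h (on this read-out lower numbers stand for stronger inhibition and higher numbers for weaker inhibition), and carries the lowest number of the three measured so far, though both gaps to the others lie within the scatter: compound 1 `COc1ccc([C@@H]2CC(=O)c3c(O)cc(OCc4cn(Cc5cccc(C#N)c5)nn4)cc3O2)cc1O` gives 18000 nM and compound 2 `COc1ccc([C@@H]2CC(=O)c3c(O)cc(OCc4cn(CCCO)nn4)cc3O2)cc1O` gives 16700 nM. Compound 4 `CCCCn1cc(COc2cc(O)c3c(c2)O[C@H](c2ccc(OC)c(O)c2)CC3=O)nn1` is not yet measured; it differs from compound 3 by propyl in place of 2-methylphenyl on a saturated chain carbon bound to an aromatic nitrogen. The steps at the same carbon bear on it: a 1.1-fold lower number from compound 1 to compound 2 (0.03 log units; within the scatter), a 1.4-fold lower number from compound 1 to compound 3 (0.14 log units; within the scatter) and a 1.3-fold lower number from compound 2 to compound 3 (0.11 log units; within the scatter), each within the scatter, whether a substituted phenyl or the 2-hydroxyethyl chain sits there. No step beyond the scatter is therefore expected for a 1.1-fold higher number from compound 3 to compound 4 (0.03 log units; within the scatter). Compound 4 is estimated at 14000 nM in this assay, with a range of 6000 nM to 35000 nM.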

Compound 4, half-maximal inhibitory concentration: 13900 nM
Compound 4: the middle estimate sits 1.0-fold (0.00 log units) above what was measured; the measured number falls inside the stated range.
By their numbers in this assay, from the lowest: compounds 3, 4, 2 and 1 (each within the scatter of the next).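

At the saturated chain carbon bound to an aromatic nitrogen, propyl, an open carbon chain with no ring, stands level with both aryl groups in this assay (a 1.1-fold higher number from compound 3 to compound 4 (0.03 log units; within the scatter); a 1.3-fold lower number from compound 1 to compound 4 (0.11 log units; within the scatter)). Methyl in place of hydroxy also stays within the scatter (a 1.2-fold lower number from compound 2 to compound 4 (0.08 log units; within the scatter)), so among these compounds, losing the aromatic ring or the hydroxy moves nothing beyond it. No evidence on the origin of this flat response is available. Still open, going by these compounds, is whether any group at this carbon, such as an amine, a carboxylic acid or a much longer chain, gives a step beyond the scatter. Changes to the shared core also remain open.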